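The compounds below may be only part of what the source reports. "The series", "measured", "known", "first", "only" and "open" are said of these compounds alone.

Compound 3, `Fc1ccc(Cc2ccc3c(NCCCNCc4ccco4)ccnc3c2)cc1`, belongs to a small set built on one shared core. In an ADME assay for permeability, using PAMPA, with a stated time of 30 min, at pH 7.4 (on this read-out higher numbers stand for higher permeability and lower numbers for lower permeability), compound 3 gives 23 10^-6 cm/s. Its two relatives carry other groups on the same saturated chain carbon bound to an aromatic carbon: compound 1, `CC(C)Cc1ccc2c(NCCCNCc3ccco3)ccnc2c1`, gives 23 10^-6 cm/s, and compound 2, `CC(C)CCc1ccc2c(NCCCNCc3ccco3)ccnc2c1`, gives 23 10^-6 cm/s. The measured steps among them are no change at the digits printed from compound 1 to compound 2 (within the scatter), no change at the digits printed from compound 1 to compound 3 (within the scatter) and no change at the digits printed from compound 2 to compound 3 (within the scatter), so compound 3 stands level with both relatives, and swapping the group at this position has so far left the read-out unmoved.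

The next compound, compound 4, `FC(F)(F)c1cccc(Cc2ccc3c(NCCCNCc4ccco4)ccnc3c2)c1`, differs from compound 3 in one place: 3-(trifluoromethyl)phenyl in place of 4-fluorophenyl on a saturated chain carbon bound to an aromatic carbon. All three measured steps bear on this change, as each also exchanges the group on the saturated chain carbon bound to an aromatic carbon, and none moved the read-out beyond the scatter. The step from compound 3 to compound 4 is therefore expected to be no change at the digits printed from compound 3 to compound 4 (within the scatter), with no movement beyond the scatter. Compound 4 is estimated at 23 10^-6 cm/s, within a range from 12 10^-6 cm/s to 40 10^-6 cm/s.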

Compound 4, apparent permeability: 23 10^-6 cm/s
Compound 4: middle estimate and measured number agree at the digits printed, within the range that was stated.
By their numbers in this assay, from the lowest: compounds 1, 2, 3 and 4 (each within the scatter of the next).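

In this assay, 3-(trifluoromethyl)phenyl, with 10 heavy atoms in place of the 7 of 4-fluorophenyl, gives no change at the digits printed from compound 3 to compound 4 (within the scatter), and the comparisons with the isobutyl and isopropyl relatives read the same: no change at the digits printed from compound 2 to compound 4 (within the scatter) and no change at the digits printed from compound 1 to compound 4 (within the scatter). On this saturated chain carbon bound to an aromatic carbon, four different groups now stand level, and a group with 3 fluorine atoms rather than 1 fits that picture as well. Nothing available here explains why the read-out holds steady at this position.

On these data alone, the groups of compound 3 and compound 4 both count no hydrogen-bond donors, no hydrogen-bond acceptors and no net charge, so the outcome with an amine or a carboxylic acid in this place stays open. Changes elsewhere, on the shared core itself, stay open too.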